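The source may report more compounds than this note shows. Statements on the series, on what has been measured and on what is new or still open speak of the compounds shown alone.

Among the compounds with values here, compound 2 `CN1C(=O)CC[C@H]1C(=O)NCc1cccc(C(F)(F)F)c1Br` gives 7.1 nM in an assay on HEK293 cells for displacement of a labelled ligand from P2X purinoceptor 7 (Homo sapiens), read by scintillation counting and radioligand binding, with a stated time of 30 min (a higher number here means a weaker inhibitor, a lower number a stronger inhibitor), the lowest of the two numbers so far, while compound 1 `CN1C(=O)CC[C@H]1C(=O)NCc1cccc(C(F)(F)F)c1F` gives 153 nM in this assay. Within the data shown here, the only step that bears on the next change is a 22-fold lower number from compound 1 to compound 2 (1.33 log units; beyond the scatter). Compound 3 `CN1C(=O)CC[C@H]1C(=O)NCc1cccc(C(F)(F)F)c1I` carries the change (iodo in place of bromo on an aromatic carbon), a further move along the same series of halogens. Because a 22-fold lower number from compound 1 to compound 2 (1.33 log units; beyond the scatter) was already large, only a small further step in the same direction is expected. Compound 3 is therefore expected at 5 nM, between 1.8 nM and 14 nM. This estimate means a 1.4-fold lower number from compound 2 to compound 3 (0.15 log units; within the scatter).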

Compound 3, half-maximal inhibitory concentration: 5.3 nM
Estimate against measurement, compound 3: 1.1-fold (0.03 log units) below; measured number inside the range.
By their numbers in this assay, from the lowest: compounds 3 and 2 (each within the scatter of the next); then compound 1.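

In this assay the exchange of bromo for iodo on this aromatic carbon, ortho to a trifluoromethyl group, gives a 1.3-fold lower number from compound 2 to compound 3 (0.13 log units; within the scatter) and so leaves the two halogens indistinguishable. The large difference from fluoro is not peculiar to bromo, since iodo in place of fluoro gives a 29-fold lower number from compound 1 to compound 3 (1.46 log units; beyond the scatter) and the same separation appears. No data here offer an explanation for this. The compounds shown leave open how a hydrogen, a methyl, a methoxy or a nitrile would compare at this position, and whether chloro would fall with fluoro or with bromo and iodo.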